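The source may hold more compounds than are shown below. What is called first, only, known or untested is meant among the compounds shown, and "the series" means these compounds.

Measured so far:
compound 1 `C#CCOc1ccc(/C=C/C(=O)c2ccc(Br)cc2)cc1` with 34%
compound 2 `O=C(/C=C/c1ccc(OCc2cn(Cc3ccccc3)nn2)cc1)c1ccc(Br)cc1` with 34%

In a functional assay on A549 cells (Homo sapiens) for inhibition, read by MTT assay, with a stated time of 48 h, tested at 10 uM (a higher number here means more inhibition of growth at the concentration tested, a lower number less inhibition of growth), compound 2 gives 34%, level with the value of compound 1 at the digits shown, a difference within the scatter. Compound 3 `O=C(/C=C/c1ccc(OCc2cn(Cc3ccc(Br)cc3)nn2)cc1)c1ccc(Br)cc1` differs from compound 2 by bromo in place of hydrogen on an aromatic carbon. Among the compounds with values here, no measured pair shows what this change does in this assay, so no direction can be read from the data. The step from compound 2 to compound 3 is expected to stay within the scatter, no change at the digits printed from compound 2 to compound 3 (within the scatter). Compound 3 is therefore estimated to give 34%, in the range 22% to 48%.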

Compound 3, percent growth inhibition at one concentration: 27%
Estimate against measurement, compound 3: 7 percentage points above, within the range that was stated.
By their numbers in this assay, from the lowest: compounds 3, 1 and 2 (each within the scatter of the next).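

In this assay, within the data shown here, the first measured pair for this change, going from benzyl to 4-bromobenzyl gives a number 7 percentage points lower from compound 2 to compound 3 (within the scatter) and so leaves growth inhibition without a clear shift. A bromo on this aromatic carbon, para to a large group, is therefore accommodated at the concentration tested, though it brings no clear gain. Nothing measured here bears on why the number holds. Still open, as far as these compounds go, is whether a different group at this place, such as an amine or a carboxylic acid, would move the number beyond the scatter.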